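Replacing the benzimidazolyl group of compound 3

This account rests on a few compounds, and the source may have more. Where it says the series, first, only, none or still open, it means among the compounds named here.

compound 1 `CN(C)CCn1c(N)c(-c2nc3ccccc3n2C)c2nc(C#N)c(C#N)nc21`: > 50000 nM (a limit)
compound 2 `CCN(CC)CCCn1c(N)c(-c2nc3ccccc3n2C)c2nc(C#N)c(C#N)nc21`: 6750 nM
compound 3 `CCN(CC)CCCCn1c(N)c(-c2nc3ccccc3n2C)c2nc(C#N)c(C#N)nc21`: 2890 nM

All values come from a functional assay on cells (Homo sapiens) for antiproliferative activity, read by MTT assay, with a stated time of 48 h; a higher number here means a weaker inhibitor, a lower number a stronger inhibitor. The value of compound 1 is a limit and not a number. Compound 3 holds the lower of the two actual numbers, against compound 2 at 6750 nM.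

Compound 4 `CCN(CC)CCCCn1c(N)c(-c2nc3cc(Cl)ccc3[nH]2)c2nc(C#N)c(C#N)nc21` carries 5-chloro-1H-benzimidazol-2-yl in place of 1-methyl-1H-benzimidazol-2-yl on an aromatic carbon. The measured steps change only the chain: an at least 7.4-fold lower number from compound 1 to compound 2 (0.86 log units; beyond the scatter), an at least 17-fold lower number from compound 1 to compound 3 (1.23 log units; beyond the scatter) and a 2.3-fold lower number from compound 2 to compound 3 (0.37 log units; beyond the scatter). None tests this group, so they give only a scale, and the direction remains a tentative expectation. A modest step is expected: a 1.9-fold lower number from compound 3 to compound 4 (0.28 log units; within the scatter). For compound 4 the estimate is 1500 nM, with an expected range of 400 nM to 6000 nM.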

Compound 4, half-maximal inhibitory concentration: 2840 nM
Compound 4: the middle estimate sits 1.9-fold (0.28 log units) below what was measured; measured number inside the range.
By their numbers in this assay, from the lowest: compounds 4 and 3 (each within the scatter of the next); then compound 2. At a limit, above all of these: compound 1.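

At the aromatic carbon next to the ring atom that bears an amino group, the first change away from the chain gives a 1.0-fold lower number from compound 3 to compound 4 (0.01 log units; within the scatter) in this assay. The swap removes the methyl, adds chlorine and brings in a hydrogen-bond donor all at once, so a level result cannot be assigned to any one of these. No measurement shown bears on why the numbers stay level.

Open, going by these compounds, is how the unsubstituted 1H-benzimidazol-2-yl and 5-chloro-1-methyl-1H-benzimidazol-2-yl groups would compare, as these would separate the methyl from the chlorine. Also open, on these data alone, is whether an amine or a carboxylic acid in place of the chlorine would leave the number unchanged.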